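One ring swapped on the amide carbonyl

The source may report more compounds than this note shows. Statements on the series, on what has been measured and on what is new or still open speak of the compounds shown alone.

Measured so far:
compound 1 `CCCCCCCCCCCC[C@@H](O)[C@H]1CC[C@H]([C@H](O)CCCCCCCCCCNC(=O)c2cccs2)O1` gives 1820 nM 
compound 2 `CCCCCCCCCCCC[C@@H](O)[C@H]1CC[C@H]([C@H](O)CCCCCCCCCCNC(=O)c2cncs2)O1` gives 19100 nM 

In a functional assay on DMS-273 cells (Homo sapiens) for inhibition, read by colorimetric assay and sulforhodamine B assay, with a stated time of 48 h (a higher number here means a weaker inhibitor of growth, a lower number a stronger inhibitor of growth), compound 2 stands at 19100 nM and holds the higher of the two numbers, which makes it the weaker growth inhibitor of the pair. Compound 3 `CCCCCCCCCCCC[C@@H](O)[C@H]1CC[C@H]([C@H](O)CCCCCCCCCCNC(=O)c2ccnn2C)O1` keeps the shared core and alters only the ring on the amide: 1-methyl-1H-pyrazol-5-yl in place of 1,3-thiazol-5-yl on a carbonyl carbon here 1-methyl-1H-pyrazol-5-yl comes in place of 1,3-thiazol-5-yl on a carbonyl carbon.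

For the measured compounds named here, only one measured step bears on this change, and it is a 10-fold higher number from compound 1 to compound 2 (1.02 log units; beyond the scatter) with 1,3-thiazol-5-yl in place of thiophen-2-yl at the same place. That step is large, so an exchange of ring at this place can clearly move the number in this assay by a wide margin. Going by the values given here, no measured compound carries the incoming ring, so the direction remains uncertain. Since compound 1 at 1820 nM shows that lower numbers are reachable here, a moderate move downward is expected, smaller than the measured step.

The expected change is a 2.4-fold lower number from compound 2 to compound 3 (0.38 log units; beyond the scatter) in this estimate. For compound 3 the estimated value is 8000 nM with an expected range from 2000 nM to 28000 nM in this assay.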

Compound 3, concentration for 50% growth inhibition: 5750 nM
Compound 3: the middle estimate sits 1.4-fold (0.14 log units) above what was measured; the measured number falls inside the stated range.
By their numbers in this assay, from the lowest: compound 1; then compound 3; then compound 2.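

In this assay, the change to 1-methyl-1H-pyrazol-5-yl on the carbonyl carbon gives a 3.3-fold lower number from compound 2 to compound 3 (0.52 log units; beyond the scatter), so a ring exchange at this place can also bring the number down and not only push it up. Thiophen-2-yl still holds the lowest number of the three, with a 3.2-fold higher number from compound 1 to compound 3 (0.50 log units; beyond the scatter), which places the 1-methyl-1H-pyrazol-5-yl compound between the other two. Compound 2 and compound 3 each carry one five-membered aromatic ring with 2 hetero atoms, 0 hydrogen-bond donors and 2 hydrogen-bond acceptors, yet their numbers differ beyond the scatter, so these counts alone do not settle the number at this place. No measurement at hand accounts for the order of the three rings.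

Still open, on these data alone, is whether a phenyl or pyridine ring on the carbonyl carbon would give a number lower than that of thiophen-2-yl. As far as these compounds go, it is also open what the methyl group contributes, a question that the unmethylated pyrazole ring would address, and whether the order of these rings would hold with a shorter chain between the amide and the shared core.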